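This account rests on a few compounds, and the source may have more. Where it says the series, first, only, none or still open, it means among the compounds named here.

Working notes on the series

Of the compounds shown here, three of the shared core have been measured in a functional assay on A549 cells (Homo sapiens) for cytotoxicity, read by sulforhodamine B assay, with a stated time of 2 days, tested at 100 uM; a higher number here means more inhibition at the concentration tested (going by the name of the read-out), a lower number less inhibition. Compound 1 `O=C(Nn1c(-c2cccc([N+](=O)[O-])c2)nc2c(-c3ccc(Cl)cc3)n[nH]c2c1=O)c1cccnc1` gives 19.7%. Compound 2 `COc1cccc(-c2nc3c(-c4ccc(Cl)cc4)n[nH]c3c(=O)n2NC(=O)c2ccncc2)c1` gives 46%, and compound 3 `COc1cccc(-c2nc3c(-c4ccc(C5CCNCC5)cc4)n[nH]c3c(=O)n2NC(=O)c2ccncc2)c1` gives 32.4%. Compound 2 therefore stands highest of the three numbers: the step of a number 13.6 percentage points lower from compound 2 to compound 3 (beyond the scatter), and compound 1 lies further below compound 2 still. Compound 1 and compound 2 differ in more than one place, so their two values are noted only as they stand.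

The next compound, compound 4 `COc1cccc(-c2nc3c(-c4ccc(Cl)cc4)n[nH]c3c(=O)n2NC(=O)c2ccccc2)c1`, keeps everything of compound 2 except the acyl group on the amide-type nitrogen: phenyl in place of pyridin-4-yl on a carbonyl carbon. For the measured compounds named here, no measured step touches this carbonyl carbon; the only single-point step, from compound 2 to compound 3, sits on an aromatic carbon of a different ring and was modest. Going by the values given here, there is thus no direct precedent for exchanging a (pyridin-4-yl)carbonyl for a benzoyl here, and no step beyond the scatter is expected in this assay in either direction.

Compound 4 is accordingly estimated at 42% in this assay, within 22% to 62%, an expected step of a number 4 percentage points lower from compound 2 to compound 4 (within the scatter), with the wide range reflecting the absence of any comparable measured change.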

Compound 4, a percentage reported as inhibition, at one concentration (the size of the read-out at that concentration, not a potency): 81.8%
Compound 4: middle estimate off by 39.8 percentage points, on the low side; the measured number lies above the stated range.
By their numbers in this assay, from the lowest: compound 1; then compound 3; then compound 2; then compound 4.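

For the compounds shown here, the carbonyl carbon on the amide-type nitrogen is a far more sensitive place in this assay than the earlier compounds showed: phenyl in place of pyridin-4-yl gives a number 35.8 percentage points higher from compound 2 to compound 4 (beyond the scatter), well beyond the only earlier single-point change, a number 13.6 percentage points lower from compound 2 to compound 3 (beyond the scatter), made on an aromatic carbon of a different ring. The exchange leaves the count at 6 heavy atoms and no net charge on both sides, and what differs is the ring nitrogen, with 1 hydrogen-bond acceptor in the group that leaves and 0 in the group that enters, so a one-atom change in this ring is enough for a large step. No available evidence bears on why this exchange has such an effect.

From the compounds shown here alone, it remains open whether the benzoyl gives a comparable step on the background of compound 3, and whether other groups on this carbonyl carbon, such as a cyclohexyl ring or a phenyl ring carrying an amine or a carboxylic acid, would keep the higher number. Going by these compounds, all the values come from a single concentration, so how compound 4 and compound 2 compare in potency also stays open.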